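Swapping a Trifluoroethoxy for a Trifluoromethoxy on the Aryl Ether

The compounds below may be only part of what the source reports. "The series", "measured", "known", "first", "only" and "open" are said of these compounds alone.

Going by the values given here, compound 1, with the structure `O=C(NNC(=O)C1CC1c1ccc(OCC(F)(F)F)cc1)c1ccncc1`, is one of three compounds measured in a functional assay on A549 cells (Homo sapiens) for inhibition, read by MTT assay, with a stated time of 72 h (a higher number here means a weaker inhibitor, a lower number a stronger inhibitor), where compound 1 gives 10000 nM. This is the lowest number of the three: compound 2, with the structure `CC(C)=CCC/C(C)=C/COc1ccc(C2CC2C(=O)NNc2nncc3ccccc23)cc1`, gives 36000 nM, and compound 3, with the structure `O=C(NNc1nncc2ccccc12)C1CC1c1ccc(OC(F)(F)F)cc1`, gives 87000 nM, both gaps lying beyond the scatter. Compound 4, with the structure `O=C(NNC(=O)C1CC1c1ccc(OC(F)(F)F)cc1)c1ccncc1`, has not yet been measured. It differs from compound 1 in one place: trifluoromethyl in place of 2,2,2-trifluoroethyl on an oxygen on an aromatic ring. Among the compounds with values here, one measured step bears on this change, since the group that enters is the same and sits at the same place on the shared core, even though the group that leaves is a different chain: a 2.4-fold higher number from compound 2 to compound 3 (0.38 log units; beyond the scatter). Carried over to the present pair, that step suggests a modest rise in the number for compound 4, in the direction of weaker inhibition. Compound 4 is therefore expected to give 20000 nM in this assay, within a range of 8000 nM to 50000 nM, so that the estimated step is a 2.0-fold higher number from compound 1 to compound 4 (0.30 log units; within the scatter).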

Compound 4, half-maximal inhibitory concentration: 56000 nM
Estimate against measurement, compound 4: 2.8-fold (0.45 log units) below; measured number above the stated range.
By their numbers in this assay, from the lowest: compound 1; then compounds 2, 4 and 3 (each within the scatter of the next, the first and the last beyond it).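

In this assay, going from 2,2,2-trifluoroethoxy to trifluoromethoxy gives a 5.6-fold higher number from compound 1 to compound 4 (0.75 log units; beyond the scatter) on the shared core. The earlier step at this place replaced 3,7-dimethylocta-2,6-dien-1-yl, a far longer chain, but here the two groups differ by only one carbon, and even this small edit moves the number beyond the scatter. The direction also repeats, with a 2.4-fold higher number from compound 2 to compound 3 (0.38 log units; beyond the scatter) as the other case, so in both pairs shown the entry of trifluoromethyl goes with weaker inhibition, although each pair has its own core.

The compounds shown give no measured reason for this shift. Going by these compounds, it also remains open how a plain ethyl group or a longer chain such as 3,3,3-trifluoropropyl on this oxygen would compare on the core of compound 1.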